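Swapping a fused indole for a fluorophenyl: expected potency loss

The source may hold more compounds than are shown below. What is called first, only, known or untested is meant among the compounds shown, and "the series" means these compounds.

Measured compounds:
- Compound 1, `COc1ccc2c(OCc3nnc4sc(-c5cc6ccccc6n5C)nn34)ccnc2c1`: in a functional assay on EBC-1 cells (Homo sapiens) for antiproliferative activity, with a stated time of 72 h (on this read-out higher numbers stand for weaker inhibition and lower numbers for stronger inhibition), compound 1 gives 149 nM
- Compound 3, `COc1cccc(-c2nn3c(COc4ccnc5cc(OC)ccc45)nnc3s2)c1`: in this assay compound 3 gives 472 nM
- Compound 2, `COc1ccc2c(OCc3nnc4sc(-c5cc6cc(F)ccc6[nH]5)nn34)ccnc2c1`: in this assay compound 2 gives "not determined" (no result reported), so no result was reported for compound 2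

All three share the same core, and they differ only in the aromatic group attached to the five-membered sulfur-containing ring. Compound 2 therefore stands nowhere on the numbers shown; it cannot be placed relative to compound 1 or compound 3.

Compound 4, `COc1ccc2c(OCc3nnc4sc(-c5ccc(F)cc5)nn34)ccnc2c1`, is compound 2 with one change: 4-fluorophenyl in place of 5-fluoro-1H-indol-2-yl on an aromatic carbon. Going by the values given here, the only measured step that resembles this is the one in which a fused two-ring indole group was replaced by a single six-membered ring; there a 3.2-fold higher number from compound 1 to compound 3 (0.50 log units; beyond the scatter). On these data alone, the change from compound 2 to compound 4 is of the same kind, a fused two-ring group giving way to a single ring, so a weakening of similar size is expected, from a starting point that is unknown and is taken here to be near compound 1. Compound 4 is expected to give 500 nM, with a range from 150 nM to 1600 nM.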

Compound 4, half-maximal inhibitory concentration: 187 nM
The estimate for compound 4 lay 2.7-fold (0.43 log units) above the measured number; measured number inside the range.
By their numbers in this assay, from the lowest: compounds 1 and 4 (each within the scatter of the next); then compound 3.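

In this assay, 4-fluorophenyl in place of 1-methyl-1H-indol-2-yl gives a 1.3-fold higher number from compound 1 to compound 4 (0.10 log units; within the scatter), so at this position a single six-membered ring can match a fused indole group within the scatter. Among the single rings, the choice of group matters: 4-fluorophenyl in place of 3-methoxyphenyl gives a 2.5-fold lower number from compound 3 to compound 4 (0.40 log units; beyond the scatter), so the higher number of compound 3 cannot be put down simply to the absence of a fused ring. Nothing available here offers an explanation for these differences.

On these data alone, without a number for compound 2, its step to compound 4 cannot be read, and the effect of the 5-fluoro-1H-indol-2-yl group stays unknown. Also open, as far as these compounds go, is how a phenyl ring carrying an amine or a carboxylic acid would behave at this carbon.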